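Removing the 3-hydroxyphenyl group from compound 3

A few compounds are considered here, and "the series" means these few. Any claim that something is new, unique, unknown or untested is made for them only; others in the source may bear on it.

Compounds measured in a functional assay on HCT-116 cells (Homo sapiens) for antiproliferative activity, read by CellTiter-Glo, with a stated time of 72 h; on this read-out higher numbers stand for weaker inhibition and lower numbers for stronger inhibition:
- compound 1 `O=C(NO)c1cccc(/C=C/c2ccnc(-c3cc(F)ccc3O)c2)c1`: 3890 nM
- compound 2 `O=C(NO)c1cccc(/C=C/c2ccnc(-c3ccccc3O)c2)c1`: 3360 nM
- compound 3 `O=C(NO)c1ccc(/C=C/c2ccnc(-c3cccc(O)c3)c2)cc1`: 1610 nM
- compound 4 `O=C(NO)c1ccc(/C=C/c2ccncc2)cc1`: not yet measured

Compound 3 gives the lowest of the three numbers in this assay, and compound 2 and compound 1 both lie beyond the scatter above it. Compound 4 follows from compound 3 with hydrogen in place of 3-hydroxyphenyl on an aromatic carbon, next to the ring nitrogen: hydrogen in place of 3-hydroxyphenyl on an aromatic carbon. Among the compounds with values here, only one measured step is available, a 1.2-fold lower number from compound 1 to compound 2 (0.06 log units; within the scatter), and it swaps fluoro for hydrogen, a far smaller change. Within the data shown here, no measured compound shows what losing the whole group does, so that step gives only weak guidance. The expectation therefore rests on the general spread of the series, and it is held loosely. The expected change is a 1.9-fold higher number from compound 3 to compound 4 (0.27 log units; within the scatter), a modest move toward a higher number with wide uncertainty. Compound 4 is estimated at 3000 nM, with an expected range from 800 nM to 11000 nM.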

Compound 4, half-maximal inhibitory concentration: 3910 nM
Estimate against measurement, compound 4: 1.3-fold (0.12 log units) below; the measured number falls inside the stated range.
By their numbers in this assay, from the lowest: compound 3; then compounds 2, 1 and 4 (each within the scatter of the next).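

In this assay, replacing the 3-hydroxyphenyl group with hydrogen on the aromatic carbon next to the ring nitrogen gives a 2.4-fold higher number from compound 3 to compound 4 (0.39 log units; beyond the scatter), a step beyond the scatter, whereas the fluoro-to-hydrogen swap gave only a 1.2-fold lower number from compound 1 to compound 2 (0.06 log units; within the scatter), a step within it. The modest size of this step shows that the group adds to the activity at this position but is not required, since compound 4, which carries only hydrogen there, still gives 3910 nM in the same assay. Nothing shown here explains the shift.

On these data alone, it remains open whether the hydroxyl or the aromatic ring itself accounts for the difference, which an unsubstituted phenyl group at this position would address. A methyl group or a 3-aminophenyl group there would show how much size and which ring substituent matter.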